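Anilinothiazole chalcones on PC-3 cells: a limit-bound series

The compounds below may be only part of what the source reports. "The series", "measured", "known", "first", "only" and "open" are said of these compounds alone.

The three measured compounds share one core and differ only in their two outer aryl groups. Compound 1 `COc1ccc(/C=C/C(=O)c2sc(Nc3ccc(Cl)cc3)nc2C)cc1` carries a methoxy on the aromatic carbon that compound 2 `Cc1nc(Nc2ccc(Cl)cc2)sc1C(=O)/C=C/c1ccccc1` has as hydrogen, and compound 3 `Cc1ccccc1Nc1nc(C)c(C(=O)/C=C/c2ccc(Cl)cc2)s1` moves the chlorine to the other end while placing a methyl on the anilino ring. In a functional assay on PC-3 cells (Homo sapiens) for cytotoxicity, read by MTT assay (a higher number here means a weaker inhibitor, a lower number a stronger inhibitor), compound 1 gives only a limit, > 25000 nM. In this assay compound 2 gives 24600 nM. Among the compounds with values here, the step of an at least 1.0-fold lower number from compound 1 to compound 2 (0.00 log units; that floor lies within the scatter) is therefore no step at all. In this assay compound 3 likewise gives only a limit, > 25000 nM, so it stands with compound 1 at the limit described by the limit of > 25000 nM in this assay, at which 2 of the 3 values shown sit; nothing here separates it from compound 2.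

Compound 4 `Cc1nc(Nc2cccc(Cl)c2)sc1C(=O)/C=C/c1ccc(Cl)cc1` is not yet measured. The change from compound 3 is 3-chlorophenyl in place of 2-methylphenyl on a nitrogen on an aromatic ring. Within the data shown here, no measured pair changes the anilino ring, so the only guide is that every measured value sits at or beside the same ceiling. Compound 4 is therefore expected to show a number no higher from compound 3 to compound 4 (the limit leaves the size open), which is no movement beyond the scatter. The estimate for compound 4 in this assay is 25000 nM, within 8000 nM to 60000 nM, with a real chance that only a limit is reported.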

Compound 4, half-maximal inhibitory concentration: > 25000 nM
Compound 4 ended at the assay's limit; the forecaster's own chance of this, stated with the estimate: 60%; the middle value lies on the limit itself.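

Within the data shown here, compound 3 and compound 4 both end as limits in this assay, so no step between them can be read, and the swap of 2-methylphenyl for 3-chlorophenyl has no measurable size. The compounds shown leave open whether any change to the outer aryl groups would bring a clearly lower number than the one most of them share: the limit of > 25000 nM in this assay, at which 3 of the 4 values shown sit.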